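Amino in Place of Hydrogen on the Core of Compound 1

The source may hold more compounds than are shown below. What is called first, only, known or untested is meant among the compounds shown, and "the series" means these compounds.

Measured compounds:
compound 1, `ClCc1ccc(Cn2cnc3c(Cl)ncnc32)cc1`, 1120 nM
compound 2, `ClCc1cccc(Cn2cnc3c(Cl)nc(Cl)nc32)c1`, 1620 nM

Of the compounds shown here, two have been measured in a functional assay on HCT-116 cells (Homo sapiens) for cytotoxicity, read by sulforhodamine B assay, with a stated time of 48 h; on this read-out higher numbers stand for weaker inhibition of growth and lower numbers for stronger inhibition of growth. Compound 1 gives 1120 nM, and compound 2 gives 1620 nM. The two numbers lie within the usual scatter of each other, so neither compound can be set apart from the other on this read-out, and compound 1 stands simply as one of two closely matched results.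

Compound 3, `Nc1nc(Cl)c2ncn(Cc3ccc(CCl)cc3)c2n1`, has not yet been measured in this assay. Compared with compound 1 it carries amino in place of hydrogen on an aromatic carbon. Going by the values given here, no pair of measured compounds shows what an amino group at this place does, so the expectation rests on the two measured numbers alone. The account expects only a small step, in either direction, and most likely nothing beyond the scatter, as the estimated step of a 1.3-fold higher number from compound 1 to compound 3 (0.13 log units; within the scatter) shows. For compound 3 the estimated value in this assay is 1500 nM, with a range from 500 nM to 4500 nM.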

Compound 3, concentration for 50% growth inhibition: 2750 nM
Estimate against measurement, compound 3: 1.8-fold (0.26 log units) below, and the stated range covers the measured number.
By their numbers in this assay, from the lowest: compounds 1, 2 and 3 (each within the scatter of the next, the first and the last beyond it).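

Amino in place of hydrogen, on the aromatic carbon between two ring nitrogen atoms, gives the first single-change step that can be read in this assay: a 2.5-fold higher number from compound 1 to compound 3 (0.39 log units; beyond the scatter), a modest shift toward weaker inhibition of growth. This position is therefore not indifferent on this read-out, as one added heavy atom, a nitrogen, is enough to carry the number beyond the scatter while the rest of compound 1 stays unchanged. No measurement on these compounds offers an explanation for the step.

Going by these compounds alone, with only this one pair, it remains open whether the shift belongs to amino in particular or would follow any replacement of hydrogen at this carbon, and a methyl group, a hydroxyl group or a methylamino group there would help to separate the two readings. From the compounds shown here alone, it is equally open whether the same change would give a step of similar size on a compound differing elsewhere, for instance one with a different group in place of the chloro group on the shared core.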